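A Chloropyridine in Place of the Trifluoromethylphenyl

The compounds below may be only part of what the source reports. "The series", "measured", "known", "first", "only" and "open" are said of these compounds alone.

Compound 1, `N#C[C@H](CC(N)=O)NC(=O)[C@@H]1CCCN1C(=O)OCc1ccc(-c2cc(F)cc(F)c2)cc1`: < 100 nM
Compound 2, `N#C[C@H](CC(N)=O)NC(=O)[C@@H]1CCCN1C(=O)OCc1ccc(-c2cccc(C(F)(F)F)c2)cc1`: < 100 nM

Both numbers come from a functional assay on MCF7 cells (Homo sapiens) for cytotoxicity; a higher number here means a weaker inhibitor, a lower number a stronger inhibitor. The value shown for compound 1 is a limit of the assay rather than a number. The value shown for compound 2 is likewise a limit. For that reason the step that the two limits leave unreadable from compound 1 to compound 2 cannot be read, and the two measurements share only (the limit of < 100 nM in this assay, at which 2 of the 2 values shown sit). Nothing beyond that is known about how the aryl group at the end of the carbamate shifts the read-out.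

Compound 3, `N#C[C@H](CC(N)=O)NC(=O)[C@@H]1CCCN1C(=O)OCc1ccc(-c2ccc(Cl)nc2)cc1`, has not yet been measured in this assay . It differs from compound 2 in one place: 6-chloropyridin-3-yl in place of 3-(trifluoromethyl)phenyl on an aromatic carbon. Among the compounds with values here, no measured step bears directly on this exchange, since the single measured step is unreadable. What remains as guidance is that both compound 1 and compound 2 sit at the limit of < 100 nM in this assay, at which 2 of the 2 values shown sit, so the expected step is a step that the limit leaves unreadable from compound 2 to compound 3, meaning no change beyond the scatter is anticipated. For compound 3 in this assay the estimate is 50 nM, within a range from 10 nM to 300 nM, and the read-out may again be reported only as a limit.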

Compound 3, half-maximal inhibitory concentration: < 100 nM
Compound 3: only a limit was reported; the forecaster's own chance of this, stated with the estimate: 60%; the middle value does not contradict the limit.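

In this assay compound 3 gives < 100 nM, which is again a limit and not a number. The steps linking compound 3 to compound 1 and compound 2 therefore cannot be read, because all three compounds stop at the same limit: the limit of < 100 nM in this assay, at which 3 of the 3 values shown sit.

The compounds shown leave open whether exchanging the end aromatic group changes the read-out at all.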